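Methoxy in Place of Fluoro on the Aryl of Compound 3

The compounds below may be only part of what the source reports. "The series", "measured", "known", "first", "only" and "open" are said of these compounds alone.

Of the compounds shown here, three sharing one core have been measured in a functional assay with Homo sapiens as the target; on this read-out higher numbers stand for weaker inhibition and lower numbers for stronger inhibition. Compound 1 `Cc1c(C(=O)Nc2ccc(C(F)(F)F)cc2)cnn1Cc1ccc(F)cc1` gives 3600 nM. Compound 2 `Cc1c(C(=O)Nc2ccc(C(F)(F)F)cc2)cnn1-c1ccc([N+](=O)[O-])cc1` gives 5700 nM. Compound 3 `Cc1c(C(=O)Nc2ccc(C(F)(F)F)cc2)cnn1-c1cccc(F)c1` gives 3100 nM, the lowest of the three numbers, though it sits close to compound 1, with a 1.2-fold lower number from compound 1 to compound 3 (0.06 log units; within the scatter), and only a little further from compound 2, with a 1.8-fold lower number from compound 2 to compound 3 (0.26 log units; within the scatter); all three values lie within the scatter of one another, so no order among them can be claimed.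

Compound 4 `COc1cccc(-n2ncc(C(=O)Nc3ccc(C(F)(F)F)cc3)c2C)c1` differs from compound 3 by methoxy in place of fluoro on an aromatic carbon. Within the data shown here, no measured step swaps one substituent for another on that six-membered aromatic ring of carbon only; the known steps, a 1.6-fold higher number from compound 1 to compound 2 (0.20 log units; within the scatter) and a 1.2-fold lower number from compound 1 to compound 3 (0.06 log units; within the scatter), exchange the whole group on the aromatic nitrogen and stay within the scatter. On that basis no shift beyond the scatter is expected for compound 4, so a 1.1-fold higher number from compound 3 to compound 4 (0.05 log units; within the scatter) is the estimated step. Compound 4 is therefore expected to give about 3500 nM in this assay, with a likely range from 1500 nM to 8500 nM.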

Compound 4, half-maximal inhibitory concentration: 2500 nM
Compound 4: middle estimate off by 1.4-fold (0.15 log units), on the high side, within the range that was stated.
By their numbers in this assay, from the lowest: compounds 4, 3, 1 and 2 (each within the scatter of the next, the first and the last beyond it).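

Among these compounds, at this aromatic carbon, meta to a large group, compound 4 gives the first measured exchange of one substituent for another on the ring: methoxy in place of fluoro stays within the scatter in this assay (a 1.2-fold lower number from compound 3 to compound 4 (0.09 log units; within the scatter)). Taking the whole group on the aromatic nitrogen, 3-methoxyphenyl in place of 4-fluorobenzyl also stays within the scatter (a 1.4-fold lower number from compound 1 to compound 4 (0.16 log units; within the scatter)), whereas 3-methoxyphenyl in place of 4-nitrophenyl gives the first step in the series beyond it, though only a modest one (a 2.3-fold lower number from compound 2 to compound 4 (0.36 log units; beyond the scatter)). No measurement of any property bears on these steps.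

From the compounds shown here alone, whether a hydroxy group, an amine or a longer chain such as ethoxy on that aromatic carbon would move the number beyond the scatter remains open. Also open, going by these compounds, is whether the step from compound 2 follows from the nitro group or from its place on the ring, as compound 2 and compound 4 differ in both.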